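Swapping the Benzyl Group on a Shared Core

The compounds below may be only part of what the source reports. "The series", "measured", "known", "first", "only" and "open" are said of these compounds alone.

Three measured compounds share one core and differ only in the group on a saturated chain carbon bound to a nitrogen on an aromatic ring. Compound 1 `OC[C@H]1O[C@@H](n2cnc3c(NCc4ccccc4F)ncnc32)[C@H](O)[C@@H]1O` carries a 2-fluorophenyl there; in a functional assay on K562 cells (Homo sapiens) for antiproliferative activity, with a stated time of 72 h (a higher number here means a weaker inhibitor, a lower number a stronger inhibitor), compound 1 gives 33200 nM. Compound 2 `OC[C@H]1O[C@@H](n2cnc3c(NCc4ccccc4Cl)ncnc32)[C@H](O)[C@@H]1O` carries a 2-chlorophenyl; in this assay compound 2 gives 64000 nM, and the step of a 1.9-fold higher number from compound 1 to compound 2 (0.29 log units; within the scatter) is small. Compound 3 `OC[C@H]1O[C@@H](n2cnc3c(NCc4ccc(F)c(F)c4F)ncnc32)[C@H](O)[C@@H]1O` carries a 2,3,4-trifluorophenyl; in this assay compound 3 reaches only a limit, > 166000 nM. The steps of an at least 5.0-fold higher number from compound 1 to compound 3 (0.69 log units; beyond the scatter) and an at least 2.5-fold higher number from compound 2 to compound 3 (0.41 log units; beyond the scatter) both point toward weaker inhibition for compound 3. Among the two plain numbers, compound 2 stands highest, though its gap to compound 1 lies within the scatter.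

Compound 4 `Cc1ccc(O)c(CNc2ncnc3c2ncn3[C@@H]2O[C@H](CO)[C@@H](O)[C@H]2O)c1` is not yet measured. Its change from compound 2 is 2-hydroxy-5-methylphenyl in place of 2-chlorophenyl on a saturated chain carbon bound to a nitrogen on an aromatic ring. For the measured compounds named here, no measured step exchanges a halogen for a hydroxyl or a methyl, so the known steps bear only loosely on it: the halogen swap barely moved the number (a 1.9-fold higher number from compound 1 to compound 2 (0.29 log units; within the scatter)), while heavier fluorination did (an at least 2.5-fold higher number from compound 2 to compound 3 (0.41 log units; beyond the scatter)). For compound 2 to compound 4 the expected step is a 1.3-fold lower number from compound 2 to compound 4 (0.11 log units; within the scatter), likely within the scatter but uncertain. Compound 4 is estimated at 50000 nM, between 15000 nM and 170000 nM.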

Compound 4, half-maximal inhibitory concentration: 16500 nM
The estimate for compound 4 lay 3.0-fold (0.48 log units) above the measured number; the range from low to high includes it.
By their numbers in this assay, from the lowest: compounds 4, 1 and 2 (each within the scatter of the next, the first and the last beyond it). At a limit, above all of these: compound 3.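

For the compounds shown here, at this position, the first group without a halogen changes the picture: 2-hydroxy-5-methylphenyl in place of 2-chlorophenyl gives a 3.9-fold lower number from compound 2 to compound 4 (0.59 log units; beyond the scatter) in this assay, so the earlier finding that swapping one halogen for another barely moved the number does not extend to every change here. The same group in place of 2-fluorophenyl gives a 2.0-fold lower number from compound 1 to compound 4 (0.30 log units; within the scatter), so the result depends on the group it replaces, and this change does not separate the two compounds. In place of 2,3,4-trifluorophenyl it gives an at least 10-fold lower number from compound 3 to compound 4 (1.00 log units; beyond the scatter), and that step rests on a limit rather than a plain number: the limit of > 166000 nM in this assay, at which 1 of the 4 values shown sits.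

The hydroxyl and the methyl enter together in 2-hydroxy-5-methylphenyl, so the compounds shown cannot say how much of the step from the 2-chlorophenyl group belongs to each, and 2-hydroxyphenyl or 3-methylphenyl alone would be needed to pull them apart. They also leave open how an amine or a carboxylic acid on the phenyl ring would read at this position.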